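Ureas on a shared core: cyclopentyl to dichlorophenyl

The source may report more compounds than this note shows. Statements on the series, on what has been measured and on what is new or still open speak of the compounds shown alone.

Compound 1 `O=C(Nc1cccc(CNc2nccnc2Cl)c1)Nc1ccccc1Cl`: 8560 nM
Compound 2 `O=C(Nc1ccccc1)Nc1cccc(CNc2nccnc2Cl)c1`: 15600 nM
Compound 3 `O=C(Nc1cccc(CNc2nccnc2Cl)c1)NC1CCCC1`: 18400 nM

All three were tested in a functional assay on HepG2 cells (Homo sapiens) for antiproliferative activity, read by MTT assay, with a stated time of 48 h; on this read-out lower numbers stand for stronger inhibition and higher numbers for weaker inhibition. Compound 3 sits within the scatter of compound 2, while a 2.1-fold higher number from compound 1 to compound 3 (0.33 log units; beyond the scatter) is a modest step beyond it. Compound 4 `O=C(Nc1cccc(CNc2nccnc2Cl)c1)Nc1ccc(Cl)cc1Cl` carries 2,4-dichlorophenyl in place of cyclopentyl on an amide-type nitrogen. Among the measured compounds shown here, the steps that bear on this are a 1.2-fold higher number from compound 2 to compound 3 (0.07 log units; within the scatter) and a 2.1-fold higher number from compound 1 to compound 3 (0.33 log units; beyond the scatter); between those two, a 1.8-fold higher number from compound 1 to compound 2 (0.26 log units; within the scatter), so a single chloro on an aromatic carbon changed little. For the measured compounds named here, no measured pair shows the effect of a second chloro. Reversing the modest step to compound 3 and adding a second chloro, compound 4 is expected to give a somewhat lower number, a 2.6-fold lower number from compound 3 to compound 4 (0.42 log units; beyond the scatter). The estimate for compound 4 is 7000 nM, with a range from 3000 nM to 16000 nM.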

Compound 4, half-maximal inhibitory concentration: 7230 nM
Estimate against measurement, compound 4: 1.0-fold (0.01 log units) below; the measured number falls inside the stated range.
By their numbers in this assay, from the lowest: compounds 4, 1, 2 and 3 (each within the scatter of the next, the first and the last beyond it).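

In this assay, 2,4-dichlorophenyl on the amide-type nitrogen gives a lower number than cyclopentyl, a 2.5-fold lower number from compound 3 to compound 4 (0.41 log units; beyond the scatter), and a lower number than phenyl, a 2.2-fold lower number from compound 2 to compound 4 (0.33 log units; beyond the scatter). Adding the second chloro shows no change that can be told from scatter, a 1.2-fold lower number from compound 1 to compound 4 (0.07 log units; within the scatter), although 2,4-dichlorophenyl clears the scatter against phenyl and 2-chlorophenyl does not. Nothing measured here explains these steps. As far as these compounds go, whether a methoxy or trifluoromethyl group on the phenyl ring would lower the number further stays open, as does the effect of an amine or a longer chain on that nitrogen.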